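Dimethylamino to 4-Hydroxybenzylamino: Expectation for Compound 3

The compounds below may be only part of what the source reports. "The series", "measured", "known", "first", "only" and "open" are said of these compounds alone.

In a functional assay on DLD-1 cells (Homo sapiens) for inhibition, read by MTT assay, with a stated time of 72 h (on this read-out lower numbers stand for stronger inhibition and higher numbers for weaker inhibition), two compounds have been measured.
Compound 1 `COc1cc(Oc2cccc(Nc3ccccc3)c2)cc(OC)c1CNCc1ccccc1` gives 5220 nM.
Compound 2 `COc1cc(Oc2cccc(Nc3ccccc3)c2)cc(OC)c1CN(C)C` gives > 20000 nM, which is a limit of the assay.

Compound 2 therefore stands at the weak end of the numbers shown, the step of an at least 3.8-fold higher number from compound 1 to compound 2 (0.58 log units; beyond the scatter) ending at the limit of > 20000 nM in this assay, at which 1 of the 2 values shown sits. Compound 3 `COc1cc(Oc2cccc(Nc3ccccc3)c2)cc(OC)c1CNCc1ccc(O)cc1` differs from compound 2 by (4-hydroxybenzyl)amino in place of dimethylamino on a saturated chain carbon bound to an aromatic carbon. Only the measured step from compound 1 to compound 2 bears on this change, which largely restores the benzylamino of compound 1 with a hydroxy added. Compound 3 is therefore expected to move by an at least 4.0-fold lower number from compound 2 to compound 3 (0.60 log units; beyond the scatter) in this assay. Compound 3 is estimated at 5000 nM, between 1500 nM and 16000 nM.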

Compound 3, half-maximal inhibitory concentration: 2690 nM
For compound 3 the middle estimate is 1.9-fold (0.27 log units) above the measured one; the measured number falls inside the stated range.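

In this assay, (4-hydroxybenzyl)amino in place of dimethylamino on this saturated chain carbon gives an at least 7.4-fold lower number from compound 2 to compound 3 (0.87 log units; beyond the scatter). That step has only a bound, as compound 2 is a limit of the assay: the limit of > 20000 nM in this assay, at which 1 of the 3 values shown sits. The added hydroxy gives a 1.9-fold lower number from compound 1 to compound 3 (0.29 log units; within the scatter), so this change does not separate compound 3 from compound 1 in this assay.

The compounds shown leave open how a methoxy or a fluorine in place of that hydroxy would read. They also leave open how a phenethylamino in place of the benzylamino would read.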